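The source may hold more compounds than are shown below. What is called first, only, known or untested is meant among the compounds shown, and "the series" means these compounds.

Within the data shown here, compound 2 `CCCCCCCCCCc1ccc(-c2noc([C@@H]3CCC[C@@H](N)C3)n2)cc1` is one of two compounds measured in an assay on HeLa cells for inhibition of sphingosine-1-phosphate transporter SPNS2 (Mus musculus), read by LC-MS, tested at 2 uM; on this read-out higher numbers stand for more inhibition at the one concentration tested (going by the name of the read-out) and lower numbers for less inhibition. In this assay compound 2 gives 13%, and compound 1 `CCCCCCCCCCc1ccc(-c2noc(CCCN(C)C)n2)cc1` gives 8%; the two sit within the scatter of each other. Compound 3 `CCCCCCCCCCc1ccc(-c2noc([C@@H](N)CCCN)n2)cc1` differs from compound 2 by 1,4-diaminobutyl in place of 3-aminocyclohexyl on an aromatic carbon. Among the measured compounds shown here, the only measured step that bears on this change, also an exchange of one amine-bearing group for another, is a number 5 percentage points higher from compound 1 to compound 2 (within the scatter). Compound 3 is therefore expected to show no step beyond the scatter, an expected change of a number 1 percentage points lower from compound 2 to compound 3 (within the scatter). The estimate for compound 3 in this assay is 12%, with a range from 0% to 30%.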

Compound 3, a percentage reported as inhibition, at one concentration (the size of the read-out at that concentration, not a potency): 40%
Beside the measured number, compound 3's estimate is 28 percentage points below it; the whole stated range lies below it.
By their numbers in this assay, from the lowest: compounds 1 and 2 (each within the scatter of the next); then compound 3.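

Among these compounds, with 1,4-diaminobutyl in place of 3-aminocyclohexyl, this assay shows a number 27 percentage points higher from compound 2 to compound 3 (beyond the scatter) and thus the first step beyond the scatter at this position. Against 3-(dimethylamino)propyl, the same group gives a number 32 percentage points higher from compound 1 to compound 3 (beyond the scatter) and so stands apart from both other amine-bearing groups. Nothing given here explains these steps.

The compounds shown leave open whether the second amine, the absence of a ring or the single defined stereocentre accounts for the rise. Also open, going by these compounds, is how a longer diamine chain, or a carboxylic acid in place of the second amine, would read.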